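A few compounds are considered here, and "the series" means these few. Any claim that something is new, unique, unknown or untested is made for them only; others in the source may bear on it.

Compound 3 `COc1cc(-c2nn(-c3cccc(NC(=O)Nc4ccc(Cl)c(Cl)c4)c3)cc2-c2ccncc2)ccc1Cl` stands in a functional assay on SN12C cells (Homo sapiens) for inhibition, read by sulforhodamine B assay, with a stated time of 48 h (a higher number here means a weaker inhibitor of growth, a lower number a stronger inhibitor of growth), only at a limit, > 50000 nM. Compound 2 `COc1cc(-c2nn(-c3cccc(NC(=O)c4cccc(C(F)(F)F)c4)c3)cc2-c2ccncc2)ccc1Cl` likewise shows only a limit, > 50000 nM. The step that the two limits leave unreadable from compound 2 to compound 3 is therefore unreadable because the limit of > 50000 nM in this assay, at which 2 of the 3 values shown sit, covers both ends of it. Among the measured compounds shown here, compound 1 `COc1cc(-c2nn(-c3cccc(NC(=O)Nc4cc(C(F)(F)F)cc(C(F)(F)F)c4)c3)cc2-c2ccncc2)ccc1Cl`, the other urea in the set, gives 3320 nM, the only number that is not a limit.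

Compound 4 `COc1cc(-c2nn(-c3cccc(NC(=O)Nc4cccc(C(F)(F)F)c4)c3)cc2-c2ccncc2)ccc1Cl` differs from compound 3 by 3-(trifluoromethyl)phenyl in place of 3,4-dichlorophenyl on an amide-type nitrogen. For the measured compounds named here, no measured step covers this exchange; compound 1 carries two trifluoromethyl groups on the same terminal ring and is the nearest point of comparison. Compound 4 is therefore expected to sit between the number for compound 1 and the limit, at an estimated 15000 nM within 3000 nM to 60000 nM. The step expected from compound 3 to compound 4 is an at least 3.3-fold lower number from compound 3 to compound 4 (0.52 log units; beyond the scatter).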

Compound 4, concentration for total growth inhibition: 21900 nM
Beside the measured number, compound 4's estimate is 1.5-fold (0.16 log units) below it, and the stated range covers the measured number.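

The urea terminal ring now gives a readable number, with an at least 2.2-fold lower number from compound 3 to compound 4 (0.35 log units; beyond the scatter) and, against the amide, an at least 2.2-fold lower number from compound 2 to compound 4 (0.35 log units; beyond the scatter), and both steps rest on a limit: the limit of > 50000 nM in this assay, at which 2 of the 4 values shown sit.

The second trifluoromethyl group also counts, with a 6.6-fold higher number from compound 1 to compound 4 (0.82 log units; beyond the scatter) when hydrogen replaces it, so a single trifluoromethyl group on the terminal ring gives a number but a weaker one.

As far as these compounds go, whether the trend follows the number of trifluoromethyl groups or where they sit on the ring stays open. Also open, from the compounds shown here alone, is whether a nitrile or a morpholine on that ring would hold the number.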